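Methoxy for chloro on the benzyl arm of compound 1

The compounds below may be only part of what the source reports. "The series", "measured", "known", "first", "only" and "open" are said of these compounds alone.

Measured compounds:
compound 1 `CN1CCN(c2nc(N)nc(Cc3ccc(Cl)cc3)n2)CC1`, 52 nM
compound 2 `CN1CCN(c2nc(N)nc(Cc3cccc(F)c3)n2)CC1`, 64 nM

In an assay on HEK293 cells for displacement of a labelled ligand from 5-hydroxytryptamine receptor 6 (Homo sapiens) (on this read-out higher numbers stand for weaker inhibition and lower numbers for stronger inhibition), compound 1 gives 52 nM, the lowest of the two numbers shown. Compound 2 gives 64 nM, and the change a 1.2-fold higher number from compound 1 to compound 2 (0.09 log units; within the scatter) lies within the scatter, so the two compounds cannot be ordered. The unmeasured compound 3 `COc1ccc(Cc2nc(N)nc(N3CCN(C)CC3)n2)cc1` differs from compound 1 by a single change: methoxy in place of chloro on an aromatic carbon. Among the measured compounds shown here, only one measured step touches the same part of the shared core, the swap of the halogenated phenyl in the step of a 1.2-fold higher number from compound 1 to compound 2 (0.09 log units; within the scatter), and it moved the number hardly at all. A methoxy in place of chloro is a different kind of exchange, so a step no larger than the scatter is expected for compound 3 in this assay, with a slight lean toward a higher number, a 1.5-fold higher number from compound 1 to compound 3 (0.19 log units; within the scatter). Compound 3 is thus estimated at 80 nM, in the range 30 nM to 250 nM.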

Compound 3, inhibition constant: 440 nM
Compound 3: middle estimate off by 5.5-fold (0.74 log units), on the low side, and the stated range ends below it.
By their numbers in this assay, from the lowest: compounds 1 and 2 (each within the scatter of the next); then compound 3.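

In this assay, the exchange of chloro for methoxy on an aromatic carbon, para to a large group, gives an 8.5-fold higher number from compound 1 to compound 3 (0.93 log units; beyond the scatter). Among the compounds shown here, the number therefore does respond to what sits on this ring, which the only earlier step, a 1.2-fold higher number from compound 1 to compound 2 (0.09 log units; within the scatter), did not reveal. No measurement at hand bears on the cause of the larger step.

The compounds shown leave open whether this step is particular to methoxy, since the effect of a hydroxy, a methyl or an ethoxy on the same aromatic carbon remains unknown. As far as these compounds go, it also remains open whether a methoxy on the ring carbon that carries fluoro in compound 2 would give a step of similar size.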